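The compounds below may be only part of what the source reports. "The series", "measured", "known", "first", "only" and "open" are said of these compounds alone.

Compound 1 `Cc1cc(Cl)ccc1NC(=O)Nc1nc(Sc2c[nH]c3ccccc23)cc(N2CCN(Cc3ccccc3)CC2)n1` and compound 2 `O=C(Nc1ccccc1)Nc1nc(Sc2c[nH]c3ccccc23)cc(N2CCN(Cc3ccccc3)CC2)n1` share one core and differ only in the group on an amide-type nitrogen. In a functional assay on A549 cells (Homo sapiens) for inhibition, with a stated time of 72 h (a higher number here means a weaker inhibitor, a lower number a stronger inhibitor), compound 1 gives > 50000 nM, which is a limit of the assay and not a number. In this assay compound 2 likewise gives only a limit, > 50000 nM. The step that the two limits leave unreadable from compound 1 to compound 2 is therefore unreadable in size and direction, and compound 2 stands at the limit rather than at any measured number; the whole evidence on the measured pair is the limit of > 50000 nM in this assay, at which 2 of the 2 values shown sit. Compound 3 `COc1ccc(NC(=O)Nc2nc(Sc3c[nH]c4ccccc34)cc(N3CCN(Cc4ccccc4)CC3)n2)cc1` carries the change (methoxy in place of hydrogen on an aromatic carbon). Among the compounds with values here, no measured step reads on this change, since both known values sit at the limit (the limit of > 50000 nM in this assay, at which 2 of the 2 values shown sit). The expected step of a number no higher from compound 2 to compound 3 (the limit leaves the size open) is accordingly placed at no movement, with no direction readable. For compound 3 the estimated value in this assay is 50000 nM, with range 15000 nM to 150000 nM, most probably again reported only as a limit.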

Compound 3, half-maximal inhibitory concentration: 42300 nM
Beside the measured number, compound 3's estimate is 1.2-fold (0.07 log units) above it; the range from low to high includes it.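

In this assay, within the data shown here, compound 3 gives the first number of the series rather than a limit, with methoxy on the aromatic carbon para to a large group. Methoxy in place of hydrogen gives an at least 1.1-fold lower number from compound 2 to compound 3 (0.07 log units; that floor lies within the scatter), and 4-methoxyphenyl in place of 4-chloro-2-methylphenyl gives an at least 1.1-fold lower number from compound 1 to compound 3 (0.07 log units; that floor lies within the scatter). Both steps are floors only, so this position accepts methoxy with a readable value, but no true size of gain is shown, and the other two values remain limits of the assay: the limit of > 50000 nM in this assay, at which 2 of the 3 values shown sit.

The true distance of compound 1 and compound 2 from compound 3 remains unreadable. Also open, going by these compounds, is whether an amine, a hydroxyl or ethoxy at this position would move the number further than methoxy does.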